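A few compounds are considered here, and "the series" means these few. Any claim that something is new, unique, unknown or untested is made for them only; others in the source may bear on it.

In a physicochemical assay for solubility, read by HPLC, measured as thermodynamic solubility, with a stated time of 24 h, at pH 4 (a lower number here means a less soluble compound, a higher number a more soluble compound), the three measured compounds give these numbers:

Compound 1 `CCCCc1ccc(NC(=O)COc2cc(C)nc3ccc(OC)cc23)cc1` gives 50000 nM
Compound 2 `COc1ccc2nc(C)cc(OCC(=O)Nc3ccc4c(c3)CCC4)c2c1` gives 120000 nM
Compound 3 `COc1ccc2nc(C)cc(OCC(=O)Nc3ccc(C)cc3)c2c1` gives 2100000 nM

Compound 3 has the highest number of the three, and both steps toward it are beyond the scatter: a 42-fold higher number from compound 1 to compound 3 (1.62 log units; beyond the scatter) and an 18-fold higher number from compound 2 to compound 3 (1.24 log units; beyond the scatter). Each of those steps takes carbon away from the ring on the amide side, and each raises the number in this assay.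

Compound 4 `COc1ccc2nc(C)cc(OCC(=O)Nc3ccc(C)c(C)c3)c2c1` differs from compound 3 by methyl in place of hydrogen on an aromatic carbon. Both measured steps bear on this change, since it moves in the opposite direction, adding carbon to the same ring. They were large, but they removed more than one carbon, so a smaller step downward is expected here, still beyond the scatter.

Compound 4 is therefore expected to give 500000 nM in this assay, with a range from 150000 nM to 1500000 nM. This estimate means a step of a 4.2-fold lower number from compound 3 to compound 4 (0.62 log units; beyond the scatter).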

Compound 4, solubility: 410000 nM
Compound 4: middle estimate off by 1.2-fold (0.09 log units), on the high side; the measured number falls inside the stated range.
By their numbers in this assay, from the lowest: compound 1; then compound 2; then compound 4; then compound 3.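

In this assay, one added methyl on the ring on the amide side, ortho to the methyl already there, is enough to give a 5.1-fold lower number from compound 3 to compound 4 (0.71 log units; beyond the scatter), so a single carbon at this position has a clear effect, though a smaller one than the earlier large steps. Among these compounds, the 3,4-dimethylphenyl group also differs from the 2,3-dihydro-1H-inden-5-yl group, with a 3.4-fold higher number from compound 2 to compound 4 (0.53 log units; beyond the scatter), and across all four compounds the number falls as carbon on this ring grows, with no compound going against that order. Nothing available explains why these numbers move.

Open, as far as these compounds go, is how an amine or a carboxylic acid on this ring carbon would read in this assay, since only carbon groups appear there. Also open, from the compounds shown here alone, is whether this methyl gives a similar step on a ring lacking the other methyl.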